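This account rests on a few compounds, and the source may have more. Where it says the series, first, only, none or still open, it means among the compounds named here.

Compound 1 `CC(C)CCn1nc(-c2cccs2)c(O)c(C2=NS(=O)(=O)c3cc(OC(C)(C)C(N)=O)ccc3N2)c1=O`: 0.35 h
Compound 2 `CCC(Oc1ccc2c(c1)S(=O)(=O)N=C(c1c(O)c(-c3cccs3)nn(CCC(C)C)c1=O)N2)C(N)=O`: 0.35 h
Compound 3 `CC(C)CCn1nc(-c2cccs2)c(O)c(C2=NS(=O)(=O)c3cc(CCC(N)=O)ccc3N2)c1=O`: > 1 h, a limit of the assay and not a number

Three compounds with a shared core have been run in an in vitro ADME assay on microsomes from liver (Homo sapiens) for metabolic stability, tested at 5 uM; a higher number here means that the compound lasts longer, a lower number that the compound disappears faster. Compound 1 gives 0.35 h. Compound 2 gives 0.35 h, and the step of no change at the digits printed from compound 1 to compound 2 (within the scatter). For compound 3 the readout is > 1 h, which is a limit of the assay rather than a measured number. Compound 3 therefore stands at the limit of > 1 h in this assay, at which 1 of the 3 values shown sits, the highest point of the numbers shown. The two steps that lead to it were an at least 2.8-fold higher number from compound 1 to compound 3 (0.45 log units; beyond the scatter) and an at least 2.8-fold higher number from compound 2 to compound 3 (0.45 log units; beyond the scatter).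

Compound 4 `CC(C)CCn1nc(-c2cccs2)c(O)c(C2=NS(=O)(=O)c3cc(NC(=O)C4CC4)ccc3N2)c1=O` differs from compound 3 in one place: (cyclopropylcarbonyl)amino in place of 2-carbamoylethyl on an aromatic carbon. Among the compounds with values here, none of the measured steps covers a change of this kind; they show only that the two oxygen-linked carbamoyl chains of compound 1 and compound 2 gave the same number, and that exchanging them for the 2-carbamoylethyl chain raised it. With no closer guide, the step of an at least 1.2-fold lower number from compound 3 to compound 4 (0.09 log units; that floor lies within the scatter) is expected to stay small and could fall either way. Compound 4 is thus estimated at 0.8 h in this assay, within a range from 0.3 h to 2 h.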

Compound 4, half-life: 0.0833 h
For compound 4 the middle estimate is 9.6-fold (0.98 log units) above the measured one; the measured number lies below the stated range.
By their numbers in this assay, from the lowest: compound 4; then compounds 1 and 2 (each within the scatter of the next). At a limit, above all of these: compound 3.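

In this assay, the swap to (cyclopropylcarbonyl)amino gives an at least 12-fold lower number from compound 3 to compound 4 (1.07 log units; beyond the scatter), so the group at this aromatic carbon can pull the half-life down sharply as well as raise it, even though the groups leaving and entering both carry 1 hydrogen-bond donor, 1 hydrogen-bond acceptor and no net charge. The new group also falls short of both oxygen-linked carbamoyl chains, with a 4.2-fold lower number from compound 1 to compound 4 (0.62 log units; beyond the scatter) and a 4.2-fold lower number from compound 2 to compound 4 (0.62 log units; beyond the scatter), whereas the earlier compounds had shown only a rise from those chains. The step from compound 3 gives only a floor for the size of the change, as the value of compound 3 is a limit of the assay and not a number: the limit of > 1 h in this assay, at which 1 of the 4 values shown sits.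

The compounds shown leave open whether the fall belongs to the amide nitrogen sitting directly on the aromatic carbon or to the three-membered ring. An acetylamino group, which has the same nitrogen link without the ring, and a cyclopropyl ketone on a two-carbon chain, which has the ring without that link, would pull these two features apart.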